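Swapping Ethylamino for Vinyl at the Carbonyl

The compounds below may be only part of what the source reports. "The series", "measured", "known", "first", "only" and "open" are said of these compounds alone.

In a functional assay on M21 cells (Homo sapiens) for antiproliferative activity, with a stated time of 48 h (a higher number here means a weaker inhibitor, a lower number a stronger inhibitor), compound 1 `CCCCC(OC)c1cccc(NC(=O)NCCCCl)c1` gives 51000 nM. Compound 2 `CCNC(=O)NCc1ccc(C(C)(C)C)cc1` is recorded in this assay only as a limit, > 100000 nM, so no number fixes where it stands. That entry is the limit of > 100000 nM in this assay, at which 1 of the 2 values shown sits. Compound 3 `C=CC(=O)NCc1ccc(C(C)(C)C)cc1` has not yet been measured; it differs from compound 2 by vinyl in place of ethylamino on a carbonyl carbon. No measured step covers a change of this kind, so the direction from compound 2 is open, and nothing shown supports a shift beyond the usual scatter. Compound 3 is therefore expected near 70000 nM, within 15000 nM to 200000 nM, which amounts to an expected step of an at least 1.4-fold lower number from compound 2 to compound 3 (0.15 log units; that floor lies within the scatter).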

Compound 3, half-maximal inhibitory concentration: 72000 nM
Compound 3: the middle estimate sits 1.0-fold (0.01 log units) below what was measured; measured number inside the range.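

For the compounds shown here, with vinyl in place of ethylamino on a carbonyl carbon, this assay gives a first step for this change: an at least 1.3-fold lower number from compound 2 to compound 3 (0.14 log units; that floor lies within the scatter). On these data alone, only a floor is fixed, so the true size of the step stays unknown, and the data show no shift beyond the scatter. Compound 2 enters this step as a limit, not a number: the limit of > 100000 nM in this assay, at which 1 of the 3 values shown sits.

The compounds shown leave open how a saturated ethyl group or a longer chain would compare with vinyl on this carbonyl carbon. They also leave open whether an amine there would read differently.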